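Benzyl change from compound 3 to compound 4

The source may hold more compounds than are shown below. What is called first, only, known or untested is meant among the compounds shown, and "the series" means these compounds.

Measured compounds, with the unmeasured one last:
- compound 1 `O=C1/C(=C\c2ccccc2)c2c(ncn2COCc2ccccc2)CCN1Cc1ccc(F)cc1`: 24800 nM
- compound 2 `Cc1cc(C)cc(CN2CCc3ncn(COCc4ccccc4)c3/C(=C/c3ccccc3)C2=O)c1`: 31300 nM
- compound 3 `O=C1/C(=C\c2ccccc2)c2c(ncn2COCc2ccccc2)CCN1Cc1ccc(Cl)cc1`: 22200 nM
- compound 4 `Cc1ccccc1CN1CCc2ncn(COCc3ccccc3)c2/C(=C/c2ccccc2)C1=O`: no value yet

All values come from a functional assay on A2780 cells (Homo sapiens) for inhibition, read by MTT assay, with a stated time of 72 h; a higher number here means a weaker inhibitor, a lower number a stronger inhibitor. Compound 3, at 22200 nM, lies within the scatter of both compound 1 and compound 2, so the three form a single flat group.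

The next step is 2-methylphenyl in place of 4-chlorophenyl on a saturated chain carbon bound to an amide-type nitrogen in a ring, with 2-methylphenyl in place of 4-chlorophenyl on a saturated chain carbon bound to an amide-type nitrogen in a ring. Two measured steps change the group at this same place: a 1.3-fold higher number from compound 1 to compound 2 (0.10 log units; within the scatter) and a 1.4-fold lower number from compound 2 to compound 3 (0.15 log units; within the scatter). A third, a 1.1-fold lower number from compound 1 to compound 3 (0.05 log units; within the scatter), swaps only the halogen. All three are small and none leaves the scatter. For the measured compounds named here, no measured compound carries a 2-methylphenyl group, so these steps offer only indirect guidance, and they give no direction for the change.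

No step beyond the scatter is therefore expected in this assay. The expected change is a 1.2-fold higher number from compound 3 to compound 4 (0.09 log units; within the scatter). The estimate for compound 4 is 27000 nM, with an expected range of 15000 nM to 45000 nM.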

Compound 4, half-maximal inhibitory concentration: 25300 nM
Beside the measured number, compound 4's estimate is 1.1-fold (0.03 log units) above it; the measured number falls inside the stated range.
By their numbers in this assay, from the lowest: compounds 3, 1, 4 and 2 (each within the scatter of the next).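

In this assay, for the compounds shown here, the earlier compounds carried only 4-fluorophenyl, 4-chlorophenyl and 3,5-dimethylphenyl on a saturated chain carbon bound to an amide-type nitrogen in a ring, and 2-methylphenyl now adds a fourth group at this place without leaving the flat group: a 1.1-fold higher number from compound 3 to compound 4 (0.06 log units; within the scatter), a 1.2-fold lower number from compound 2 to compound 4 (0.09 log units; within the scatter) and a 1.0-fold higher number from compound 1 to compound 4 (0.01 log units; within the scatter). The change from 4-chlorophenyl to 2-methylphenyl keeps the count of heavy atoms and swaps chlorine for carbon, and with compound 4 every step among the four compounds lies within the scatter, so the series has no group at this place that separates from the others. No supporting measurement is available to explain this flatness.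

As far as these compounds go, all four compounds keep a substituted phenyl ring of carbon only at this place, so it remains open whether a pyridine ring, an amine, a carboxylic acid or a longer chain would give a step beyond the scatter. From the compounds shown here alone, whether changes on the shared core, rather than at this place, would move the number in this assay also remains open.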